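A longer hydroxycarbamoyl chain on the shared core

This account rests on a few compounds, and the source may have more. Where it says the series, first, only, none or still open, it means among the compounds named here.

Measured so far in a functional assay on A549 cells (Homo sapiens) for antiproliferative activity, read by CCK-8 assay, with a stated time of 72 h; on this read-out higher numbers stand for weaker inhibition and lower numbers for stronger inhibition:
- compound 1 `CCOc1cc(C(C)(C)C)ccc1C1=NC(c2ccc(Cl)cc2)C(c2ccc(Cl)cc2)N1C(=O)NCCCCCCC(=O)Nc1ccccc1N`: 16000 nM
- compound 2 `CCOc1cc(C(C)(C)C)ccc1C1=NC(c2ccc(Cl)cc2)C(c2ccc(Cl)cc2)N1C(=O)N1CCN(Cc2ccc(C(=O)NO)cc2)CC1`: 2170 nM
- compound 3 `CCOc1cc(C(C)(C)C)ccc1C1=NC(c2ccc(Cl)cc2)C(c2ccc(Cl)cc2)N1C(=O)N1CCN(CCCCC(=O)NO)CC1`: 3780 nM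

In this assay compound 3 gives 3780 nM. For the measured compounds named here, that value lies within the scatter of the one for compound 2, while compound 1 stands at a higher number, beyond the scatter of compound 3.

The next compound is compound 4 `CCOc1cc(C(C)(C)C)ccc1C1=NC(c2ccc(Cl)cc2)C(c2ccc(Cl)cc2)N1C(=O)N1CCN(CCCCCCCC(=O)NO)CC1`, which keeps everything in compound 3 except the chain: 3-(hydroxycarbamoyl)propyl in place of hydroxycarbamoyl on a saturated chain carbon, four bonds along the chain from an amine nitrogen in a ring. Cut one bond further out, the same difference reads 3-(hydroxycarbamoyl)propyl to 6-(hydroxycarbamoyl)hexyl.

Going by the values given here, only one measured step bears on this change, and only indirectly: a 1.7-fold higher number from compound 2 to compound 3 (0.24 log units; within the scatter). It exchanges the group on the amine nitrogen in a ring and stays small. Among the compounds with values here, no measured pair isolates chain length, so the evidence is thin. The expectation therefore rests on the value of compound 3, with no shift beyond the scatter foreseen and no firm direction. The expected size is a 1.3-fold lower number from compound 3 to compound 4 (0.10 log units; within the scatter), which would remain within the scatter. For compound 4 the estimated value is 3000 nM, with an expected range from 1200 nM to 7500 nM.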

Compound 4, half-maximal inhibitory concentration: 2010 nM
Compound 4: middle estimate off by 1.5-fold (0.17 log units), on the high side, and the stated range covers the measured number.
By their numbers in this assay, from the lowest: compounds 4, 2 and 3 (each within the scatter of the next); then compound 1.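

In this assay, the pair of compounds that isolates chain length gives a 1.9-fold lower number from compound 3 to compound 4 (0.27 log units; within the scatter): with 3-(hydroxycarbamoyl)propyl in place of hydroxycarbamoyl on a saturated chain carbon, four bonds along the chain from an amine nitrogen in a ring, the added length brings no shift beyond the scatter. The longer chain can also stand in for the ring-bearing group, since 6-(hydroxycarbamoyl)hexyl in place of 4-(hydroxycarbamoyl)phenyl gives a 1.1-fold lower number from compound 2 to compound 4 (0.03 log units; within the scatter), so neither chain length nor the exchange of the phenyl group for a saturated chain separates these hydroxycarbamoyl compounds in this read-out. No measurement is at hand that would account for this flat result.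

It remains open whether a chain shorter than any shown, such as (hydroxycarbamoyl)methyl on the amine nitrogen in a ring, or one longer than compound 4 carries would leave the number within the scatter as well. Going by these compounds, it is equally open whether the hydroxycarbamoyl group itself matters at the end of this chain, as a carboxylic acid or a primary amide in its place would show.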